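A few compounds are considered here, and "the series" means these few. Any claim that something is new, unique, unknown or untested is made for them only; others in the source may bear on it.

Working notes on the series.

Compound 1 `Cn1c(CN2CCC(c3ccccc3)CC2)nc2ccccc21` gives in an assay on CHO cells with metabotropic glutamate receptor 2 (Homo sapiens) as the target, read by FLIPR (a higher number here means a larger maximal response, a lower number a smaller maximal response), a value of 89%. Compound 2 `Cn1c(CN2CCC(c3ccc(Cl)cc3)CC2)nc2ccccc21` carries the change (chloro in place of hydrogen on an aromatic carbon); in this assay compound 2 gives 91%, and the step is a number 2 percentage points higher from compound 1 to compound 2 (within the scatter). Compound 3 `Cn1c(CN2CCN(c3ccc(C(F)(F)F)cn3)CC2)nc2ccccc21` is built on a different core; the difference between the two cores is not broken down here. In this assay compound 3 gives 81%, which lies within the scatter of both compound 1 and compound 2, so no order among the three can be read from these numbers.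

Compound 4 `Cn1c(CN2CCN(c3ncc(C(F)(F)F)cc3Cl)CC2)nc2ccccc21` has not been measured. It differs from compound 3 by chloro in place of hydrogen on an aromatic carbon. Within the data shown here, this is the same kind of change as the one from compound 1 to compound 2, but not the same change: there the chloro enters a six-membered aromatic ring of carbon only, para to a large group; here it enters a six-membered aromatic ring with 1 nitrogen, ortho to a large group, two atoms from the ring nitrogen and meta to a trifluoromethyl group. Among the measured compounds shown here, only one measured example of this kind of change exists, so the expectation rests on a single step. Because a number 2 percentage points higher from compound 1 to compound 2 (within the scatter) stayed within the scatter, compound 4 is expected to show a number 3 percentage points higher from compound 3 to compound 4 (within the scatter) in this assay. Compound 4 is therefore estimated at 84% in this assay, with a range from 70% to 98%.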

Compound 4, largest response reached (Emax), in percent of the reference or control that the assay uses: 71%
Compound 4: middle estimate off by 13 percentage points, on the high side, and the stated range covers the measured number.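

Chloro in place of hydrogen on an aromatic carbon, here on a six-membered aromatic ring with 1 nitrogen, gives in this assay a number 10 percentage points lower from compound 3 to compound 4 (within the scatter). Set beside the earlier step, this reading gives no sign that the change behaves differently on the two cores: the same change on two cores in this assay, a number 2 percentage points higher (within the scatter) from compound 1 to compound 2 and a number 10 percentage points lower (within the scatter) from compound 3 to compound 4, 12 percentage points apart, within the scatter of two such steps. This does not show that the change carries over unaltered or that it has no effect on either core, since each core offers a single step, both steps stay within the scatter, and the chloro sits in a different ring and a different place in each, so core and place cannot be separated.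

The compounds shown leave open whether any substituent at this place on the ring of compound 3 would give a step beyond the scatter in this assay, for instance a methoxy group, a nitrile or an amine in place of the chloro. They also leave open whether a chloro on another carbon of that ring, or the same ring with the trifluoromethyl group replaced by a methyl group, would read any differently.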